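The source may report more compounds than this note shows. Statements on the series, on what has been measured and on what is new or still open speak of the compounds shown alone.

Measured in a functional assay on MDA-MB-231 cells (Homo sapiens) for antiproliferative activity, read by MTT assay, with a stated time of 72 h; on this read-out lower numbers stand for stronger inhibition and higher numbers for weaker inhibition:
- compound 1 `CN(C)CCn1cnnc1-c1cc(Oc2ccc(NC(=O)Nc3cccc(C(F)(F)F)c3)cc2F)ccn1`: 16400 nM
- compound 2 `CN(C)CCn1cnnc1-c1cc(Oc2ccc(NC(=O)Nc3ccc(F)c(F)c3)cc2F)ccn1`: > 50000 nM (a limit, not a number)

Compound 2 sits at the limit of this assay, with no number to compare against. Compound 3 `CCN(CC)CCn1cnnc1-c1cc(Oc2ccc(NC(=O)Nc3ccc(F)c(F)c3)cc2F)ccn1` carries diethylamino in place of dimethylamino on a saturated chain carbon, two bonds along the chain from an aromatic nitrogen, with diethylamino in place of dimethylamino on a saturated chain carbon. Within the data shown here, the only measured step, an at least 3.0-fold higher number from compound 1 to compound 2 (0.48 log units; beyond the scatter), was at least modest but lies at a different place, on an amide-type nitrogen, and does not bear on this change. No step beyond the scatter is expected in this assay, and another limit is quite possible. The expected step is an at least 1.2-fold lower number from compound 2 to compound 3 (0.09 log units; that floor lies within the scatter). The estimate for compound 3 is 40000 nM, with an expected range of 15000 nM to 80000 nM.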

Compound 3, half-maximal inhibitory concentration: 41300 nM
Compound 3: middle estimate off by 1.0-fold (0.01 log units), on the low side; low and high end bracket the measured number.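

In this assay, diethylamino in place of dimethylamino on this chain gives an at least 1.2-fold lower number from compound 2 to compound 3 (0.08 log units; that floor lies within the scatter). Compound 3 gives 41300 nM, the only actual number shown for a compound carrying 3,4-difluorophenyl. Compound 2 holds a limit, not a number, so the true size of this step stays unknown: the limit of > 50000 nM in this assay, at which 1 of the 3 values shown sits.

On these data alone, whether the same change behaves alike alongside 3-(trifluoromethyl)phenyl remains open. Also open, as far as these compounds go, is whether a cyclic amine such as morpholine or pyrrolidine, or a longer chain, moves the number beyond the scatter in this assay.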